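Amide substituent series: lipophilicity of compounds 1 to 4

A few compounds are considered here, and "the series" means these few. Any claim that something is new, unique, unknown or untested is made for them only; others in the source may bear on it.

Measured so far:
compound 1, `COc1cc(-c2cc(C(=O)O)c3ccccc3n2)ccc1OCC(=O)Nc1ccc(C)cc1`: 1.2
compound 2, `COc1cc(-c2cc(C(=O)O)c3ccccc3n2)ccc1OCC(=O)Nc1ccc(Cl)cc1`: 1.5
compound 3, `COc1cc(-c2cc(C(=O)O)c3ccccc3n2)ccc1OCC(=O)NCc1cccnc1`: -0.8

In a physicochemical assay for lipophilicity, using the shake flask method, in phosphate buffer, measured as octanol-water partition, at pH 7.4 (on this read-out lower numbers stand for lower lipophilicity and higher numbers for higher lipophilicity), compound 3 gives the lowest of the three numbers; compound 1 is nearer, compound 2 further. Compound 4, `COc1cc(-c2cc(C(=O)O)c3ccccc3n2)ccc1OCC(=O)NCc1ccco1`, differs from compound 3 by furan-2-yl in place of pyridin-3-yl on a saturated chain carbon bound to an amide-type nitrogen. Going by the values given here, no measured step exchanges one heteroaryl group for another at this place. The steps that touch this position are a number 2.00 log units lower from compound 1 to compound 3 (beyond the scatter) and a number 2.30 log units lower from compound 2 to compound 3 (beyond the scatter), both large, showing that the group on the amide nitrogen moves this read-out strongly. A step back upward beyond the scatter is therefore expected, though smaller than those two. For compound 4 the expected step is a number 1.10 log units higher from compound 3 to compound 4 (beyond the scatter), giving an estimate of 0.3 with a range from -0.4 to 1.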

Compound 4, distribution coefficient: -0.3
Compound 4: middle estimate off by 0.60 log units, on the high side; the measured number falls inside the stated range.
By their numbers in this assay, from the lowest: compound 3; then compound 4; then compounds 1 and 2 (each within the scatter of the next).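

In this assay, exchanging one heteroaryl group for another on a saturated chain carbon bound to an amide-type nitrogen gives a real but modest change, a number 0.50 log units higher from compound 3 to compound 4 (beyond the scatter). The (furan-2-yl)methyl group still leaves large steps from the 4-substituted phenyl amides, a number 1.50 log units lower from compound 1 to compound 4 (beyond the scatter) and a number 1.80 log units lower from compound 2 to compound 4 (beyond the scatter), so the choice of heteroaryl group accounts for less of this range than the full exchange on the nitrogen. No evidence on the origin of these steps is available.

Going by these compounds, those large steps change the ring and the chain together, so their separate shares remain open. A phenylmethyl group on the amide-type nitrogen would help to separate them.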